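A Second Methoxy Group Added to Compound 1

The source may report more compounds than this note shows. Statements on the series, on what has been measured and on what is new or still open speak of the compounds shown alone.

Compound 1 `COc1ccc(/C=C/S(=O)(=O)Cc2ccc(OC)cc2)cc1` was tested in a functional assay on DLD-1 cells (Homo sapiens) for antiproliferative activity, read by trypan blue exclusion; a lower number here means a stronger inhibitor, a higher number a weaker inhibitor. In this assay compound 1 gives > 20000 nM, which is a limit of the assay rather than a measured number. Among the three values shown, compound 1 stands at the weak end because of the limit of > 20000 nM in this assay, at which 1 of the 3 values shown sits. Two related compounds were measured alongside it. Compound 2 `COc1ccc(CS(=O)(=O)/C=C/c2ccc(Cl)cc2)cc1` gives 3000 nM, and compound 3 `COc1ccc(CS(=O)(=O)/C=C/c2ccc([N+](=O)[O-])cc2)cc1` gives 5000 nM. The step of an at least 6.6-fold lower number from compound 1 to compound 2 (0.82 log units; beyond the scatter) and the step of an at least 4.0-fold lower number from compound 1 to compound 3 (0.60 log units; beyond the scatter) both exchange the methoxy group for another group, and both lower the number. Between the two, a 1.7-fold higher number from compound 2 to compound 3 (0.22 log units; within the scatter).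

Compound 4 `COc1ccc(CS(=O)(=O)/C=C/c2ccc(OC)c(OC)c2)cc1` differs from compound 1 by methoxy in place of hydrogen on an aromatic carbon; the original methoxy stays in place and a second one is added. For the measured compounds named here, none of the measured steps makes this kind of change, so they bear on it only loosely: they show that altering this ring can bring the number out of the limit, but not what a second methoxy does. The expectation for compound 4 is therefore an at least 1.3-fold lower number from compound 1 to compound 4 (0.12 log units; that floor lies within the scatter), a small move at most. Compound 4 is estimated at 15000 nM, with a range from 4000 nM to 60000 nM.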

Compound 4, half-maximal inhibitory concentration: > 20000 nM
Compound 4 gave a limit, no number; the forecaster's own chance of this, stated with the estimate: 45%; middle value at least 1.3-fold (0.12 log units) away from the limit.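

No new step can be read from compound 1 to compound 4, because each gives only a limit and not a measured number: the limit of > 20000 nM in this assay, at which 2 of the 4 values shown sit. The compounds shown leave open whether methoxy in place of hydrogen on an aromatic carbon changes the number at all.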